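Adding fluoro to compound 1

A few compounds are considered here, and "the series" means these few. Any claim that something is new, unique, unknown or untested is made for them only; others in the source may bear on it.

Among the compounds with values here, in a functional assay on the whole organism with Mus musculus as the target, in the maximal electroshock model (a higher number here means that more compound is needed for the effect, a lower number that less compound is needed), compound 1 (`CNC(=O)[C@@H](CO)NCc1ccc(OCc2ccccc2)cc1`) gives 22.8 mg/kg, the highest of the three numbers measured so far. Compound 2 (`CNC(=O)[C@H](CO)NCc1ccc(OCc2ccccc2)cc1`) gives 9.9 mg/kg. Compound 3 (`CC[C@@H](NCc1ccc(OCc2ccccc2)cc1)C(N)=O`) gives 7.2 mg/kg. Compound 4 (`CNC(=O)[C@@H](CO)NCc1ccc(OCc2cccc(F)c2)cc1`) keeps the core of compound 1 and differs from it in one place: fluoro in place of hydrogen on an aromatic carbon, which turns benzyl into 3-fluorobenzyl.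

Within the data shown here, no measured step covers this change. All three steps lie in the group on the amine nitrogen, so they bear on it only indirectly, as a guide to size. The modest 2.3-fold lower number from compound 1 to compound 2 (0.36 log units; beyond the scatter) comes with the fact that compounds 1 and 2 differ only in the configuration as drawn. Also modest is a 3.2-fold lower number from compound 1 to compound 3 (0.50 log units; beyond the scatter), while a 1.4-fold lower number from compound 2 to compound 3 (0.14 log units; within the scatter) stays within the scatter.

With a 3.2-fold lower number from compound 1 to compound 3 (0.50 log units; beyond the scatter) as the largest step seen, a shift no larger than that is expected in this assay, with only a weak lean towards a lower number. The expected change is a 1.5-fold lower number from compound 1 to compound 4 (0.18 log units; within the scatter), which would not clear the scatter. For compound 4 the estimated value is 15 mg/kg, with an expected range from 7 mg/kg to 30 mg/kg.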

Compound 4, dose for half-maximal effect: 13 mg/kg
Compound 4: middle estimate off by 1.2-fold (0.06 log units), on the high side; low and high end bracket the measured number.
By their numbers in this assay, from the lowest: compounds 3, 2, 4 and 1 (each within the scatter of the next, the first and the last beyond it).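

Within the data shown here, compound 4 gives the only reading on the aromatic end of the molecule, away from the amine nitrogen, and in this assay it shows a 1.8-fold lower number from compound 1 to compound 4 (0.24 log units; within the scatter). Replacing hydrogen with fluoro on this aromatic carbon, meta to a large group, therefore leaves the reading within the scatter, and activity in the whole animal is retained with 3-fluorobenzyl in place of benzyl. Nothing in the available evidence bears on this particular change, so the step stands as an observation without an explanation.

On these data alone, it remains open whether chloro, trifluoromethyl or methoxy at the same place would give a step beyond the scatter. As far as these compounds go, it is also open whether 3-fluorobenzyl behaves the same way on the cores of compound 2 and compound 3.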